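This account rests on a few compounds, and the source may have more. Where it says the series, first, only, none or still open, it means among the compounds named here.

Measured in an ADME assay on microsomes from liver (Rattus norvegicus) for metabolic stability, read by LC-MS, with a stated time of 30 min, tested at 1 uM; on this read-out higher numbers stand for fast clearance and lower numbers for slow clearance:
Compound 1 `CNCc1cc(Oc2ccc3c(ccn3C(=O)Nc3cc(C(C)C)on3)c2)ncn1`: 114 mL.min-1.g-1
Compound 2 `CNCc1cc(Oc2ccc3c(ccn3C(=O)Nc3cc(C4(C)CC4)on3)c2)ncn1`: 91 mL.min-1.g-1

Going by the values given here, compound 2 stands level with compound 1, the only other compound measured. Compound 3 `CNCc1cc(Oc2ccc3c(ccn3C(=O)Nc3cccc(C(F)(F)F)c3)c2)ncn1` has 3-(trifluoromethyl)phenyl in place of 5-(1-methylcyclopropyl)-1,2-oxazol-3-yl on an amide-type nitrogen. Among the compounds with values here, the sole measured step, a 1.3-fold lower number from compound 1 to compound 2 (0.10 log units; within the scatter), exchanged only isopropyl for 1-methylcyclopropyl, so it offers weak guidance for this larger replacement. No shift beyond the scatter is therefore expected in this assay, though the uncertainty is wide. The expected change is a 1.0-fold lower number from compound 2 to compound 3 (0.00 log units; within the scatter). For compound 3 the estimated value is 90 mL.min-1.g-1, with an expected range of 40 mL.min-1.g-1 to 200 mL.min-1.g-1.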

Compound 3, intrinsic clearance in microsomes: 43 mL.min-1.g-1
Estimate against measurement, compound 3: 2.1-fold (0.32 log units) above, and the stated range covers the measured number.
By their numbers in this assay, from the lowest: compound 3; then compounds 2 and 1 (each within the scatter of the next).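

Unlike the exchange of isopropyl for 1-methylcyclopropyl, which stayed within the scatter in this assay, replacing the substituted 1,2-oxazol-3-yl on the amide-type nitrogen with 3-(trifluoromethyl)phenyl moves the number beyond it. This gives a 2.1-fold lower number from compound 2 to compound 3 (0.33 log units; beyond the scatter) and a 2.7-fold lower number from compound 1 to compound 3 (0.42 log units; beyond the scatter), both modest and both in the direction of slower clearance. Nothing available explains this shift.

The compounds shown do not separate the contribution of the phenyl ring from that of the trifluoromethyl group. As far as these compounds go, how a nitrile or a chlorine in place of trifluoromethyl would read in this assay remains open.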